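Chain substituent at the ring nitrogen: from prenyl-type to benzyl

The source may report more compounds than this note shows. Statements on the series, on what has been measured and on what is new or still open speak of the compounds shown alone.

compound 1, `CCn1nc(-c2cccnc2)c2ccccc2c1=O`: 87%
compound 2, `C=CCn1nc(-c2cccnc2)c2ccccc2c1=O`: 70%
compound 3, `CC(C)=CCn1nc(-c2cccnc2)c2ccccc2c1=O`: 94%

In an assay on isolated protein (Oryctolagus cuniculus) with Thromboxane-A synthase (Homo sapiens) as the target, tested at 1 uM (a higher number here means more inhibition at the concentration tested (going by the name of the read-out), a lower number less inhibition), compound 3 gives the highest of the three numbers; compound 1 lies within the scatter of it, while the gap to compound 2 is beyond it, as a number 24 percentage points higher from compound 2 to compound 3 (beyond the scatter) shows. Compound 4, `O=c1c2ccccc2c(-c2cccnc2)nn1Cc1ccccc1`, carries phenyl in place of 2-methylprop-1-en-1-yl on a saturated chain carbon bound to an aromatic nitrogen. Bearing on this step are a number 7 percentage points higher from compound 1 to compound 3 (within the scatter) and a number 24 percentage points higher from compound 2 to compound 3 (beyond the scatter), both ending at the group with the most heavy atoms. Among the measured compounds shown here, no measured step goes from an open-chain group to a ring, so the direction is uncertain; the spread of the three numbers is modest, and an unchanged level or a small drop is expected. Compound 4 is therefore expected at 85%, between 65% and 97%. The expected step is a number 9 percentage points lower from compound 3 to compound 4 (within the scatter).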

Compound 4, a percentage reported as inhibition, at one concentration (the size of the read-out at that concentration, not a potency): 97%
Estimate against measurement, compound 4: 12 percentage points below; the range from low to high includes it.
By their numbers in this assay, from the lowest: compound 2; then compounds 1, 3 and 4 (each within the scatter of the next).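

In this assay, an aromatic ring is accepted on the saturated chain carbon bound to an aromatic nitrogen: benzyl stays level with the 3-methylbut-2-en-1-yl group (a number 3 percentage points higher from compound 3 to compound 4 (within the scatter)) and with the group of compound 1 (a number 10 percentage points higher from compound 1 to compound 4 (within the scatter)). Only the vinyl group stands apart (a number 27 percentage points higher from compound 2 to compound 4 (beyond the scatter)), so the low value of compound 2 remains the one clear departure in this set. Nothing available gives a reason for these levels. Open, as far as these compounds go, are a carboxylic acid or an amine on the benzyl ring and a longer chain between that ring and the nitrogen. Potency also stays open, with only one tested concentration shown.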